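Double-bond geometry change from compound 1 to compound 3

The compounds below may be only part of what the source reports. "The series", "measured", "known", "first", "only" and "open" are said of these compounds alone.

Among the compounds with values here, compound 1 `C=C/C(C)=C\C=C\C(C)CC(=O)CC(C)C` is the one member of this set with a numerical result: in a functional assay on SK-MEL-28 cells (Homo sapiens) for cytotoxicity (a lower number here means a stronger inhibitor, a higher number a weaker inhibitor), compound 1 gives 2.5 ug/mL. Compound 2 `CC(C)=C/C=C\C(C)/C=C/C=C(\C)C=O` is the other measured member. In this assay compound 2 returns only a limit, > 10 ug/mL, so no number is known for it. Compound 1 therefore stands alone with a definite value, while the remaining value sits at the limit of > 10 ug/mL in this assay, at which 1 of the 2 values shown sits.

Compound 3 `C=C/C(C)=C/C=C/C(C)CC(=O)CC(C)C` has not been measured. Relative to compound 1 the change is the two compounds have the same atoms and bonds; at least one stereo element is drawn with a configuration in one of them and without one in the other: 1 of 3 stereo elements differ; a double bond is drawn Z in compound 1 and E in compound 3. Within the data shown here, no pair of measured compounds differs in this way, so there is no measured step to lean on. The atoms and bonds are unchanged, and the expectation is that potency in this assay holds, with the step of no change at the digits printed from compound 1 to compound 3 (within the scatter) expected to stay within the scatter rather than move beyond it in either direction. Compound 3 is accordingly estimated at 2.5 ug/mL, with a range from 1 ug/mL to 8 ug/mL in this assay.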

Compound 3, half-maximal inhibitory concentration: 5 ug/mL
Estimate against measurement, compound 3: 2.0-fold (0.30 log units) below; low and high end bracket the measured number.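

The series now has its first measured step, a double bond going from Z to E with atoms and bonds unchanged: in this assay this gives a 2.0-fold higher number from compound 1 to compound 3 (0.30 log units; within the scatter). The earlier compounds shown here offered no pair differing in one place, so the geometry of this double bond could not be assessed, whereas in this assay it now reads as a change that does not separate the two compounds, and compound 3 retains measurable cytotoxicity as a definite number rather than a limit. The reading carries one qualification on how the pair is drawn: the fact that one of compounds 1 and 3 is drawn with a defined configuration and the other without, at the place where they differ.

The compounds shown leave open whether the same tolerance holds at the other double bonds of the chain, and whether a hydroxyl group or an amine in place of the ketone carbonyl would keep a definite value in this assay. Compound 2 remains a limit of the assay, > 10 ug/mL, and offers no number against which to read either question.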